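A few compounds are considered here, and "the series" means these few. Any claim that something is new, unique, unknown or untested is made for them only; others in the source may bear on it.

Working notes on the series. Of the compounds shown here, two have numbers so far. Compound 1 `CONc1nc(C#Cc2ccccn2)nc2c1ncn2[C@@H]1O[C@H](CO)[C@@H](O)[C@H]1O` carries a 2-(pyridin-2-yl)ethynyl group on its core and in an assay on CHO cells for displacement of a labelled ligand from adenosine receptor A3 (Homo sapiens) (on this read-out higher numbers stand for weaker inhibition and lower numbers for stronger inhibition), compound 1 gives 2.3 nM. Compound 2 `CNC(=O)[C@H]1O[C@@H](n2cnc3c(NOC)nc(I)nc32)[C@H](O)[C@@H]1O` carries iodo at the same position on the shared core and a methylamide on the sugar; in this assay compound 2 gives 1.7 nM. Compound 2 stands alongside compound 1, the gap between the two numbers being within the scatter, so neither is placed above the other.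

Compound 3 `CNC(=O)[C@H]1O[C@@H](n2cnc3c(NOC)nc(C#Cc4ccccn4)nc32)[C@H](O)[C@@H]1O` has not yet been measured. It differs from compound 2 by a single exchange: 2-(pyridin-2-yl)ethynyl in place of iodo on an aromatic carbon. Among the compounds with values here, no measured pair shows this exchange, but compound 1 already carries the entering group and gives 2.3 nM, so the step from compound 2 to compound 3 is expected to be small, a 1.1-fold lower number from compound 2 to compound 3 (0.05 log units; within the scatter), with no direction beyond the scatter. For compound 3 the estimate is 1.5 nM, with a range from 0.5 nM to 5 nM.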

Compound 3, inhibition constant: 1.1 nM
The estimate for compound 3 lay 1.4-fold (0.13 log units) above the measured number; low and high end bracket the measured number.
By their numbers in this assay, from the lowest: compounds 3, 2 and 1 (each within the scatter of the next, the first and the last beyond it).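

In this assay, 2-(pyridin-2-yl)ethynyl in place of iodo on the aromatic carbon between two ring nitrogen atoms gives a 1.5-fold lower number from compound 2 to compound 3 (0.19 log units; within the scatter), so this position carries a group of 8 heavy atoms with a ring and a triple bond as well as it carries a single iodine, the two numbers lying within the scatter. With 2-(pyridin-2-yl)ethynyl held fixed on the core, methylcarbamoyl in place of hydroxymethyl on a saturated ring carbon gives a 2.1-fold lower number from compound 1 to compound 3 (0.32 log units; beyond the scatter), a modest step and the only one here beyond the scatter. Nothing available bears on what lies behind the size of either step.

As far as these compounds go, whether this position also accepts a group such as an amine or a plain ethynyl without the pyridine ring stays open. So does whether the methylcarbamoyl step keeps its size with iodo on the core.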